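Notes on compound 4: dimethoxyphenyl in place of fluorohydroxyphenyl

The source may report more compounds than this note shows. Statements on the series, on what has been measured and on what is new or still open speak of the compounds shown alone.

In a functional assay on U-87MG ATCC cells (Homo sapiens) for cytotoxicity, read by MTT assay, with a stated time of 72 h (on this read-out lower numbers stand for stronger inhibition and higher numbers for weaker inhibition), compound 1 `CN(C)CCn1cnnc1-c1cc(Oc2ccc(NC(=O)N/N=C/c3ccc(F)cc3Cl)cc2F)ccn1` gives 1210 nM and compound 3 `CN(C)CCn1cnnc1-c1cc(Oc2ccc(NC(=O)N/N=C/c3cc(C(C)(C)C)cc(C(C)(C)C)c3O)cc2F)ccn1` gives 520 nM. For compound 2 `CN(C)CCn1cnnc1-c1cc(Oc2ccc(NC(=O)N/N=C/c3ccc(O)c(F)c3)cc2F)ccn1` this assay returns only a limit, > 100000 nM, so compound 2 stands apart from the other two with no number of its own. Among the measured compounds shown here, the one step into it, an at least 82-fold higher number from compound 1 to compound 2 (1.91 log units; beyond the scatter), is large and rests on the limit of > 100000 nM in this assay, at which 1 of the 3 values shown sits, rather than on a measured value.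

Compound 4 `COc1ccc(/C=N/NC(=O)Nc2ccc(Oc3ccnc(-c4nncn4CCN(C)C)c3)c(F)c2)c(OC)c1` differs from compound 2 by 2,4-dimethoxyphenyl in place of 3-fluoro-4-hydroxyphenyl on a carbon with a double bond to nitrogen. For the measured compounds named here, no measured step covers this change directly; the only step touching compound 2 is the one from compound 1, and it shows that the aryl group on that carbon moves the read-out by a wide margin. Since compound 2 sits at the limit, any number for compound 4 would mean a move downward, and the aryl groups with numbers, in compound 1 and compound 3, both sit well below the limit. Compound 4 is therefore expected to show a step of an at least 25-fold lower number from compound 2 to compound 4 (1.39 log units; beyond the scatter), with a wide uncertainty.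

For compound 4 the estimated value is 4000 nM, within 800 nM to 40000 nM.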

Compound 4, half-maximal inhibitory concentration: 12600 nM
Compound 4: the middle estimate sits 3.2-fold (0.50 log units) below what was measured; low and high end bracket the measured number.
By their numbers in this assay, from the lowest: compound 3; then compound 1; then compound 4. At a limit, above all of these: compound 2.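

In this assay, replacing 3-fluoro-4-hydroxyphenyl with 2,4-dimethoxyphenyl on a carbon with a double bond to nitrogen brings the series back to a measurable read-out, with an at least 7.9-fold lower number from compound 2 to compound 4 (0.89 log units; beyond the scatter). The size of this step is only a lower bound, as the value for compound 2 is a limit and not a number: the limit of > 100000 nM in this assay, at which 1 of the 4 values shown sits. The series now also has a step between two measured groups at this place, a 10-fold higher number from compound 1 to compound 4 (1.02 log units; beyond the scatter), so 2,4-dimethoxyphenyl and 2-chloro-4-fluorophenyl are clearly separated without recourse to the limit.

On these data alone, the exchange into compound 4 alters the hydroxy group, the fluorine and both methoxy groups together, so the contribution of each remains open. Also open, as far as these compounds go, is how an aryl group carrying a single methoxy group, an amine or a carboxylic acid would read at this place.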